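Bromo in Place of Trifluoromethyl on an Aryl Urea

The source may hold more compounds than are shown below. What is called first, only, known or untested is meant among the compounds shown, and "the series" means these compounds.

Compound 1 `CCCCCCc1ccc(NC(=O)N[C@@H](C)c2ccccc2)cc1`: 100%
Compound 2 `C[C@H](NC(=O)Nc1ccc(C(F)(F)F)cc1)c1ccccc1`: 94%

In an ADME assay on the whole organism with Oryza sativa as the target, tested at 1 uM (on this read-out higher numbers stand for a weaker effect at the one concentration tested and lower numbers for a stronger effect), compound 1 gives 100%, and compound 2 gives 94%. Compound 2 stands at the lower end of these two numbers, though its nearest neighbour, compound 1, lies within the scatter of it. Among the measured compounds shown here, the one measured step, a number 6 percentage points lower from compound 1 to compound 2 (within the scatter), was small.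

Compound 3 `C[C@H](NC(=O)Nc1ccc(Br)cc1)c1ccccc1` differs from compound 2 by bromo in place of trifluoromethyl on an aromatic carbon. That earlier step, a number 6 percentage points lower from compound 1 to compound 2 (within the scatter), touches the same place and bears on this change; it moved nothing beyond the scatter, so no step beyond the scatter is expected here either. Compound 3 is therefore estimated to give about 97%, expected between 88% and 100%. The expected step of a number 3 percentage points higher from compound 2 to compound 3 (within the scatter) is within the scatter.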

Compound 3, a percentage reported as activity, at one concentration (the size of the read-out at that concentration, not a potency): 97%
Beside the measured number, compound 3's estimate shows no gap at the digits printed; the range from low to high includes it.
By their numbers in this assay, from the lowest: compounds 2, 3 and 1 (each within the scatter of the next).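

In this assay, this aromatic carbon has now carried hexyl, trifluoromethyl and bromo, and the bromo compound shows a number close to both others: there is a number 3 percentage points higher from compound 2 to compound 3 (within the scatter), and a number 3 percentage points lower from compound 1 to compound 3 (within the scatter). Across the three compounds, a single bromine atom in place of either larger group leaves the read-out within the scatter. Nothing measured here offers an explanation for this flat result. As far as these compounds go, it remains open whether an amine or a carboxylic acid at this place would move the number beyond the scatter, and whether any group here can do so.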